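Chain Extension at the Amide Nitrogen Substituent

The compounds below may be only part of what the source reports. "The series", "measured", "known", "first", "only" and "open" are said of these compounds alone.

Measured in an assay on HEK293 cells for displacement of a labelled ligand from NPC1-like intracellular cholesterol transporter 1 (Homo sapiens); a higher number here means a weaker inhibitor, a lower number a stronger inhibitor:
Compound 1 `CC(C)(C)OC(=O)NC1CCN(C(=O)CN2CN(c3ccccc3)C3(CCN(C(=O)c4ccc(C(C)(C)C)cc4)CC3)C2=O)CC1` gives 8300 nM.
Compound 2 `CC(C)(C)OC(=O)NCCNC(=O)CN1CN(c2ccccc2)C2(CCN(C(=O)c3ccc(C(C)(C)C)cc3)CC2)C1=O` gives 10900 nM.

Compound 2 holds the higher of the two numbers, yet its gap to compound 1 lies within the scatter, so the two are not told apart in this assay. Compound 3 `CC(C)(C)OC(=O)NCCCNC(=O)CN1CN(c2ccccc2)C2(CCN(C(=O)c3ccc(C(C)(C)C)cc3)CC2)C1=O` carries ((tert-butoxycarbonyl)amino)methyl in place of (tert-butoxycarbonyl)amino on a saturated chain carbon, two bonds along the chain from an amide-type nitrogen. Among the compounds with values here, no pair of measured compounds shows this step, and compound 1 and compound 2 together suggest the linker length barely moves the number. The step from compound 2 to compound 3 is therefore expected to be small, in either direction, as a 1.1-fold lower number from compound 2 to compound 3 (0.06 log units; within the scatter). Compound 3 is estimated at 9500 nM, within 3500 nM to 26000 nM.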

Compound 3, half-maximal inhibitory concentration: 4500 nM
Compound 3: middle estimate off by 2.1-fold (0.32 log units), on the high side, and the stated range covers the measured number.
By their numbers in this assay, from the lowest: compounds 3, 1 and 2 (each within the scatter of the next, the first and the last beyond it).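

In this assay, ((tert-butoxycarbonyl)amino)methyl in place of (tert-butoxycarbonyl)amino on a saturated chain carbon, two bonds along the chain from an amide-type nitrogen, gives a 2.4-fold lower number from compound 2 to compound 3 (0.38 log units; beyond the scatter) and is the only step shown at this position. The chain position therefore responds to this small change, although the step is modest. Nothing available accounts for the shift.

As far as these compounds go, it remains open whether a longer chain carrying the same end group would lower the number further or raise it again. Equally open, from the compounds shown here alone, is how a free amine in place of (tert-butoxycarbonyl)amino would behave on this chain.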